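The source may hold more compounds than are shown below. What is called first, only, known or untested is meant among the compounds shown, and "the series" means these compounds.

Compound 1 `CC(=O)C1=C(C)NC(=O)NC1c1ccco1`: 38%
Compound 2 `CC1=C(C(=O)OC(C)(C)C)C(c2ccco2)NC(=O)N1`: 44%
Compound 3 `CCOC(=O)C1=C(C(F)(F)F)NC(=O)NC1c1ccco1`: 2%

In an assay on HEK293 cells for displacement of a labelled ligand from adenosine receptor A2b (Homo sapiens), with a stated time of 30 min, tested at 10 uM (on this read-out lower numbers stand for less inhibition and higher numbers for more inhibition at the one concentration tested (going by the name of the read-out)), compound 3 gives 2%, the lowest of the three numbers. The nearest is compound 1 with 38%, a gap beyond the scatter, and the furthest is compound 2 with 44%, also beyond the scatter. Compound 4 `CCOC(=O)C1=C(c2ccccc2)NC(=O)NC1c1ccco1` has not yet been measured in this assay. It differs from compound 3 in one place: phenyl in place of trifluoromethyl on a double-bonded ring carbon.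

Among the measured compounds shown here, the only measured step between single-change neighbours, a number 6 percentage points higher from compound 1 to compound 2 (within the scatter), touches the carbonyl substituent and not the double-bonded ring carbon, so it says little about this change; it only shows that an exchange elsewhere on the shared core stayed within the scatter. For the measured compounds named here, no measured pair exchanges the trifluoromethyl for another group. What the numbers do show is that the two compounds carrying a methyl at this ring carbon, compound 1 and compound 2, sit well above compound 3. On that limited basis a rise is expected for compound 4 in this assay, of about a number 28 percentage points higher from compound 3 to compound 4 (beyond the scatter), though with wide uncertainty. Compound 4 is therefore estimated at 30%, in a range from 5% to 60%.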

Compound 4, a percentage reported as inhibition, at one concentration (the size of the read-out at that concentration, not a potency): 28%
Beside the measured number, compound 4's estimate is 2 percentage points above it; the measured number falls inside the stated range.
By their numbers in this assay, from the lowest: compound 3; then compounds 4, 1 and 2 (each within the scatter of the next, the first and the last beyond it).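

In this assay, among the compounds shown here, the exchange of trifluoromethyl for phenyl gives a number 26 percentage points higher from compound 3 to compound 4 (beyond the scatter), and this is the first measured pair in which the double-bonded ring carbon changes while the ethoxycarbonyl and furan-2-yl groups stay fixed. It shows that the group at this position alone can move the read-out, and that a six-membered aromatic ring of carbon only can sit here with more inhibition than trifluoromethyl gives at the one concentration tested. Neither group carries hydrogen-bond donors, hydrogen-bond acceptors or a net charge, so the exchange leaves those counts unchanged, and no measurement shown explains the step.

For the compounds shown here, with only two groups compared at this ring carbon with the ethoxycarbonyl group in place, it remains open how a methyl, an amine, a longer alkyl chain or a phenyl bearing a methoxy group would read there. Going by these compounds, it also remains open whether the step would hold with the acetyl or tert-butoxycarbonyl group of the other compounds, and, as each number is a single-concentration percentage, how the compounds would compare in potency.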